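Cyclopropyl in Place of Hexyl: An Expected Result

The source may hold more compounds than are shown below. What is called first, only, known or untested is meant among the compounds shown, and "the series" means these compounds.

Measured in an assay on isolated protein for inhibition of Amine oxidase [flavin-containing] A (Homo sapiens), read by fluorescence, with a stated time of 20 min; on this read-out higher numbers stand for weaker inhibition and lower numbers for stronger inhibition:
compound 1 `CC/C(C)=N\Nc1nc(-c2cccc([N+](=O)[O-])c2)cs1` gives 20500 nM
compound 2 `C/C(CC(C)C)=N/Nc1nc(-c2cccc([N+](=O)[O-])c2)cs1` gives 4410 nM
compound 3 `CCCCCC/C(C)=N\Nc1nc(-c2cccc([N+](=O)[O-])c2)cs1` gives 10900 nM

Compound 3 has the second highest of the three numbers; its value sits within the scatter of compound 1 and beyond it from compound 2, as a 2.5-fold higher number from compound 2 to compound 3 (0.39 log units; beyond the scatter) shows. Compound 4 `C/C(=N/Nc1nc(-c2cccc([N+](=O)[O-])c2)cs1)C1CC1` differs from compound 3 by cyclopropyl in place of hexyl on a carbon with a double bond to nitrogen. Two earlier steps changed the chain at this end of the molecule: a 4.6-fold lower number from compound 1 to compound 2 (0.67 log units; beyond the scatter) and a 2.5-fold higher number from compound 2 to compound 3 (0.39 log units; beyond the scatter). Both were modest, so a modest shift is expected here too, with the number going down in this assay. For compound 4 the estimate is 5000 nM, within 1500 nM to 16000 nM, meaning an expected step of a 2.2-fold lower number from compound 3 to compound 4 (0.34 log units; beyond the scatter).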

Compound 4, half-maximal inhibitory concentration: 2660 nM
Compound 4: middle estimate off by 1.9-fold (0.27 log units), on the high side, and the stated range covers the measured number.
By their numbers in this assay, from the lowest: compounds 4 and 2 (each within the scatter of the next); then compounds 3 and 1 (each within the scatter of the next).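

Cyclopropyl, the only ring on this carbon among these compounds, gives a 4.1-fold lower number from compound 3 to compound 4 (0.61 log units; beyond the scatter) against hexyl and a 7.7-fold lower number from compound 1 to compound 4 (0.89 log units; beyond the scatter) against ethyl, so a ring is accepted at this position and goes with stronger inhibition than either chain. Against isobutyl the change gives a 1.7-fold lower number from compound 2 to compound 4 (0.22 log units; within the scatter), which leaves those two compounds unranked, so the ring offers no clear gain over every chain. Nothing available explains these differences.

As far as these compounds go, whether a larger ring such as cyclohexyl would do as well remains open. So does the effect of an amine on the chain at this carbon.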